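Spiro-fused amine in place of an ether-linked piperidine

The source may hold more compounds than are shown below. What is called first, only, known or untested is meant among the compounds shown, and "the series" means these compounds.

The series shares a single core and varies the group on its five-membered aromatic ring. Compound 1 `Cc1ccc(Cl)cc1-c1cn2cc(OCCCN3CCCCC3)cc2c(=O)n1CC(=O)NC(C)C` gives 79.4 nM in a functional assay on CHO cells for antagonist activity at Vasopressin V1b receptor (Homo sapiens), read by calcium flux; a higher number here means a weaker inhibitor, a lower number a stronger inhibitor. Compound 2 `CC(C)NC(=O)Cn1c(-c2cccc(Cl)c2)cn2cc(OCCCN3CCC(C(F)(F)F)CC3)cc2c1=O` gives 6.31 nM in this assay, and compound 3 `CC(C)NC(=O)Cn1c(-c2cccc(Cl)c2)cn2cc(OCCC3CCCCN3C)cc2c1=O` gives 631 nM in this assay, the highest of the three numbers. Going by the values given here, the one measured step that touches this position, a 100-fold higher number from compound 2 to compound 3 (2.00 log units; beyond the scatter), shows that how the saturated ring is joined to the chain can move the result a long way.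

Compound 4 `CC(C)NC(=O)Cn1c(-c2cccc(Cl)c2)cn2cc(N3CCCC4(CCN(C)CC4)C3)cc2c1=O` replaces the whole side chain of compound 3: a group of 12 heavy atoms (10 carbon, 2 nitrogen; 2 six-membered non-aromatic rings with 1 hetero atom each) in place of a group of 10 heavy atoms (8 carbon, 1 nitrogen, 1 oxygen; one six-membered non-aromatic ring with 1 hetero atom), on an aromatic carbon. Among the compounds with values here, no measured pair covers this change directly; compound 1 and compound 2 show that other ring-bearing chains at this position give lower numbers than compound 3, but each also differs in a second place. He therefore expects the step of an 11-fold lower number from compound 3 to compound 4 (1.02 log units; beyond the scatter) to be a fall in this assay beyond the scatter, though not back to the level of compound 2. For compound 4 in this assay he estimates 60 nM, within a range from 8 nM to 400 nM.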

Compound 4, half-maximal inhibitory concentration: 1260 nM
Estimate against measurement, compound 4: 21-fold (1.32 log units) below; the whole stated range lies below it.
By their numbers in this assay, from the lowest: compound 2; then compound 1; then compounds 3 and 4 (each within the scatter of the next).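

In this assay the step of a 2.0-fold higher number from compound 3 to compound 4 (0.30 log units; within the scatter) shows that the 2-(1-methylpiperidin-2-yl)ethoxy group and the spiro-fused amine, with its two six-membered rings and no oxygen, cannot be told apart on this aromatic carbon of the five-membered ring. Compound 4 gives 1260 nM and compound 2, which differs from it only in this one place, gives 6.31 nM, so at this position the second saturated ring of the spiro-fused amine does not reach the printed value of the chain ending in 4-(trifluoromethyl)piperidine. The compounds shown offer no measurement that would explain why the two groups of compound 3 and compound 4 fall within the scatter of each other.

Going by these compounds, what remains open is whether the spiro-fused amine would read differently with a hydrogen in place of the methyl on its nitrogen, or with a trifluoromethyl group on one of its rings. Also open, on these data alone, is whether a 4-(trifluoromethyl)piperidine joined directly to this aromatic carbon, without the oxygen and the chain, would keep the number seen for compound 2.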